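Methyl for bromo on the aryl ether of compound 3

A few compounds are considered here, and "the series" means these few. Any claim that something is new, unique, unknown or untested is made for them only; others in the source may bear on it.

Compound 3 `Cc1nn(C)c(Oc2ccccc2Br)c1/C=N\CCCCCCOc1cc2oc(=O)cc(C)c2cc1Cl` gives 19700 nM in a functional assay on SMMC-7721 cells (Homo sapiens) for antiproliferative activity, read by MTT assay, with a stated time of 72 h (on this read-out higher numbers stand for weaker inhibition and lower numbers for stronger inhibition), the highest number among the three measured. Compound 1 `Cc1nn(C)c(Oc2cccc(Cl)c2)c1/C=N\CCCCCCOc1cc2oc(=O)cc(C)c2cc1Cl` gives 5260 nM and compound 2 `Cc1nn(C)c(Oc2ccc(Cl)cc2)c1/C=N\CCCCCCOc1cc2oc(=O)cc(C)c2cc1Cl` gives 2080 nM. The step of a 3.7-fold higher number from compound 1 to compound 3 (0.57 log units; beyond the scatter) and the step of a 9.5-fold higher number from compound 2 to compound 3 (0.98 log units; beyond the scatter) both leave the 2-bromophenoxy compound trailing, while a 2.5-fold lower number from compound 1 to compound 2 (0.40 log units; beyond the scatter) moves the chloro around the ring. Compound 4 `Cc1ccccc1Oc1c(/C=N\CCCCCCOc2cc3oc(=O)cc(C)c3cc2Cl)c(C)nn1C` differs from compound 3 by methyl in place of bromo on an aromatic carbon. Going by the values given here, no measured step exchanges one group for another at a fixed position, so none bears directly on this change; the measured steps only show that this part of the molecule is sensitive. The expected step is a 1.6-fold lower number from compound 3 to compound 4 (0.22 log units; within the scatter), with wide uncertainty. Compound 4 is estimated at 12000 nM, range 4000 nM to 40000 nM.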

Compound 4, half-maximal inhibitory concentration: 5120 nM
For compound 4 the middle estimate is 2.3-fold (0.37 log units) above the measured one; measured number inside the range.
By their numbers in this assay, from the lowest: compound 2; then compounds 4 and 1 (each within the scatter of the next); then compound 3.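

Methyl in place of bromo is the first exchange at a fixed position in this assay (a 3.8-fold lower number from compound 3 to compound 4 (0.59 log units; beyond the scatter)), so the high number of compound 3 goes with the bromo rather than with any group at this place. The 2-methylphenyl on the oxygen cannot be told apart from the 3-chlorophenyl (a 1.0-fold lower number from compound 1 to compound 4 (0.01 log units; within the scatter)), yet it still trails the 4-chlorophenyl (a 2.5-fold higher number from compound 2 to compound 4 (0.39 log units; beyond the scatter)). Nothing on hand accounts for the bromo-to-methyl step.

On these data alone, whether 2-chlorophenyl, 2-methoxyphenyl or plain phenyl on this oxygen would fall with compound 4 or with compound 3 stays open. So does whether 4-methylphenyl would match the 4-chlorophenyl of compound 2.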